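The compounds below may be only part of what the source reports. "The series", "measured", "known", "first", "only" and "open" are said of these compounds alone.

Working notes on the series.

Compound 1 is `Nc1cc(N)c2nc(-c3ccccc3)c(Sc3ccc(F)cc3)nc2c1`. In a functional assay on LOX IMVI cells (Homo sapiens) for inhibition, read by sulforhodamine B assay, with a stated time of 48 h (on this read-out higher numbers stand for weaker inhibition of growth and lower numbers for stronger inhibition of growth), compound 1 gives 40700 nM, the highest of the three numbers measured. Compound 3, `COc1ccc(CNc2nc3cc(N)cc(N)c3nc2-c2ccccc2)cc1`, gives 27500 nM in this assay and sits within the scatter of compound 1. Compound 2, `COc1cc(CNc2nc3cc(N)cc(N)c3nc2-c2ccccc2)cc(OC)c1OC`, gives 10500 nM in this assay, and the gap to compound 1 lies beyond the scatter. Compounds 2 and 3 carry a benzylamino linker with methoxy groups on the outer ring; compound 1 carries the sulfanyl linker to a 4-fluorophenyl group.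

Compound 4 is `COc1ccc(Sc2nc3cc(N)cc(N)c3nc2-c2ccccc2)cc1` and has not yet been measured in this assay. Compound 4 differs from compound 1 as follows: methoxy in place of fluoro on an aromatic carbon, on the ring that sits para to a large group, so the sulfanyl linker of compound 1 is kept. Among the compounds with values here, no measured pair in the set carries this single change, so the size of the step cannot be read from the data. The expectation for this assay is a step of no certain direction and at most modest size, with a slight lean toward a lower number, since the two compounds with a methoxy-bearing outer ring both gave lower numbers than compound 1, with compound 2 at 10500 nM and compound 3 at 27500 nM; the difference in linker keeps this an indirect hint. The step expected in this assay is a 1.4-fold lower number from compound 1 to compound 4 (0.13 log units; within the scatter). Compound 4 is estimated at 30000 nM in this assay, with a range from 12000 nM to 75000 nM.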

Compound 4, concentration for total growth inhibition: < 100000 nM
Compound 4: no number, only a limit; the forecaster's own chance of this, stated with the estimate: 10%; the middle value is on the limit's open side.
By their numbers in this assay, from the lowest: compound 2; then compounds 3 and 1 (each within the scatter of the next).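

In this assay compound 4 gives < 100000 nM, which is a limit and not a number, so no step can be read between compound 1 and compound 4. The compounds shown leave open whether methoxy in place of fluoro on an aromatic carbon moves the number at all while the sulfanyl linker is kept.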